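Replacing a pyrrolidine with a pyridine on an isoindoline amide

A few compounds are considered here, and "the series" means these few. Any claim that something is new, unique, unknown or untested is made for them only; others in the source may bear on it.

Measured so far:
- compound 1, `C[C@H](Oc1ccc(S(C)(=O)=O)cc1C(=O)N1Cc2ccc(C(F)(F)F)cc2C1)C(F)(F)F`: 21 nM
- compound 2, `C[C@H](Oc1ccc(S(C)(=O)=O)cc1C(=O)N1Cc2ccc(N3CCCC3)cc2C1)C(F)(F)F`: 180 nM

In an assay on CHO cells for inhibition of sodium- and chloride-dependent glycine transporter 1 (Homo sapiens), read by scintillation counting (on this read-out lower numbers stand for an effect already at smaller amounts and higher numbers for an effect only at larger amounts of compound), compound 2 gives 180 nM, the higher of the two numbers; compound 1 gives 21 nM. Among the compounds with values here, the one measured step, an 8.6-fold higher number from compound 1 to compound 2 (0.93 log units; beyond the scatter), shows that the group on this aromatic carbon matters, since a trifluoromethyl was exchanged for a pyrrolidin-1-yl there and the number rose beyond the scatter.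

Compound 3, `C[C@H](Oc1ccc(S(C)(=O)=O)cc1C(=O)N1Cc2ccc(-c3ccccn3)cc2C1)C(F)(F)F`, takes the next step from compound 2: pyridin-2-yl in place of pyrrolidin-1-yl on an aromatic carbon. Both groups carry one nitrogen, but the flat six-membered aromatic pyridin-2-yl stands closer in kind to the trifluoromethyl-bearing compound 1 than the non-aromatic pyrrolidin-1-yl does, and nothing else in the structure changes.

Within the data shown here, only the step from compound 1 to compound 2 bears on this position, and it suggests that moving away from pyrrolidin-1-yl can bring the number down. For compound 3 a modestly lower number is therefore expected, a 3.0-fold lower number from compound 2 to compound 3 (0.48 log units; beyond the scatter), with the estimate 60 nM and a range from 15 nM to 250 nM.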

Compound 3, half-maximal effective concentration: 84 nM
Compound 3: middle estimate off by 1.4-fold (0.15 log units), on the low side; the range from low to high includes it.
By their numbers in this assay, from the lowest: compound 1; then compound 3; then compound 2.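

In this assay this aromatic carbon now separates three groups rather than two: there is a 2.1-fold lower number from compound 2 to compound 3 (0.33 log units; beyond the scatter) when pyridin-2-yl replaces pyrrolidin-1-yl, so part of the rise seen with the pyrrolidine is won back, but there is still a 4.0-fold higher number from compound 1 to compound 3 (0.60 log units; beyond the scatter) when pyridin-2-yl stands in place of trifluoromethyl, which leaves compound 1 with the lowest number of the set. Pyrrolidin-1-yl and pyridin-2-yl each carry one nitrogen and one hydrogen-bond acceptor. They still give numbers that differ beyond the usual scatter, so these shared counts alone do not fix the number at this position. The data offer no measurement that explains why the three groups fall in this order.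

The compounds shown leave open whether the ring nitrogen matters where it stands, which pyridin-3-yl, pyridin-4-yl or a plain phenyl ring would help to settle. From the compounds shown here alone, it also remains open whether a small group such as chlorine or a nitrile, or a different saturated amine such as morpholine, would come closer to the trifluoromethyl of compound 1.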